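A Fourth Amine Variant on a Core That Shows Only Limits

This account rests on a few compounds, and the source may have more. Where it says the series, first, only, none or still open, it means among the compounds named here.

Compound 1 `O=C1C=C(NC2CCCCC2)C(=O)c2c1nc1n2[C@H]2OC[C@@H](O)[C@H]2OC1` is examined in a functional assay on MCF7 cells (Homo sapiens) for inhibition, read by sulforhodamine B assay; on this read-out higher numbers stand for weaker inhibition and lower numbers for stronger inhibition. In this assay compound 1 gives only a limit, > 8000 nM. Compound 2 `O=C1C(N2CCCC2)=CC(=O)c2c1nc1n2[C@H]2OC[C@@H](O)[C@H]2OC1` likewise gives only a limit in this assay, > 16000 nM. Compound 3 `O=C1C(N2CCCCC2)=CC(=O)c2c1nc1n2[C@H]2OC[C@@H](O)[C@H]2OC1` also reaches only a limit in this assay, > 8000 nM. Among the compounds with values here, the single one-place step among the measured compounds, a step that the two limits leave unreadable from compound 2 to compound 3, is left unreadable by the two limits. Compound 1 therefore stands no differently from the others: every value shown is a limit, with the limit of > 8000 nM in this assay, at which 2 of the 3 values shown sit, and (the limit of > 16000 nM in this assay, at which 1 of the 3 values shown sits). Compound 4 `O=C1C=C(N2CCCC2)C(=O)c2c1nc1n2[C@H]2OC[C@@H](O)[C@H]2OC1` differs from compound 1 by pyrrolidin-1-yl in place of cyclohexylamino on a double-bonded ring carbon. No measured step bears on this change, and nothing shown separates the compounds in this assay, so compound 4 is expected to give a limit as well, estimated around 16000 nM within 6000 nM to 50000 nM. The step that the limit leaves unreadable from compound 1 to compound 4 is expected to be none beyond the scatter.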

Compound 4, half-maximal inhibitory concentration: > 16000 nM
Compound 4 was reported as a limit; the forecaster's own chance of this, stated with the estimate: 85%; the middle value sits exactly at the limit.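

Compound 1 and compound 4 both give only limits in this assay, and the step between them cannot be read. The compounds shown leave open whether any amine variant on the shared core reaches a measurable value.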